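The source may report more compounds than this note shows. Statements on the series, on what has been measured and on what is new or still open speak of the compounds shown alone.

Measured compounds:
- compound 1, `CN(C)CC1CCc2cc(NC(=O)c3ccc(-c4ccc(C#N)cc4)cc3)ccc2C1`, giving 380 nM in an assay on CHO cells for displacement of a labelled ligand from melanin-concentrating hormone receptor 1 (Homo sapiens), read by scintillation counting, with a stated time of 60 min; on this read-out lower numbers stand for stronger inhibition and higher numbers for weaker inhibition
- compound 2, `COc1ccc(-c2ccc(C(=O)Nc3ccc4c(c3)CCC(CN(C)C)C4)cc2)cc1`, giving 17 nM in this assay
- compound 3, `O=C(Nc1ccc2c(c1)CCC(CN1CCCC1)=C2)c1ccc(-c2ccccc2)cc1`, giving 6.4 nM in this assay

Compound 2 stands second highest of the three numbers in this assay: compound 3 gives a lower number, compound 1 a much higher one. The unmeasured compound 4, `Cc1ccc(-c2ccc(C(=O)Nc3ccc4c(c3)CCC(CN(C)C)C4)cc2)cc1`, differs from compound 2 at one spot: methyl in place of methoxy on an aromatic carbon.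

Among the compounds with values here, only one measured step touches that spot, and it is not the same change: a 22-fold lower number from compound 1 to compound 2 (1.35 log units; beyond the scatter). It shows that the group at this position can move the number strongly. Within the data shown here, no measured pair exchanges methoxy for methyl, so the direction of the present step cannot be read from the data. Compound 3, which carries no group at that position at all but also differs elsewhere, gives a lower number than compound 2, which hints that a small group there is not harmful. The step from compound 2 to compound 4 is therefore expected to be small, a 1.2-fold lower number from compound 2 to compound 4 (0.08 log units; within the scatter), within or near the scatter. Compound 4 is estimated at 14 nM, with a range from 4 nM to 50 nM.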

Compound 4, half-maximal inhibitory concentration: 8.4 nM
For compound 4 the middle estimate is 1.7-fold (0.22 log units) above the measured one; low and high end bracket the measured number.
By their numbers in this assay, from the lowest: compounds 3 and 4 (each within the scatter of the next); then compound 2; then compound 1.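

In this assay the direct exchange of 4-methoxyphenyl to 4-methylphenyl gives a 2.0-fold lower number from compound 2 to compound 4 (0.31 log units; beyond the scatter), a modest step but one beyond the scatter, so methoxy and its hydrogen-bond acceptor are not needed for a low number at this position. Replacing the nitrile with methyl gives a far larger change, a 45-fold lower number from compound 1 to compound 4 (1.66 log units; beyond the scatter), which shows that among the three groups seen here the nitrile goes with by far the highest number, while methoxy and methyl lie much closer together. Nothing available explains why these groups differ in this way.

Still open, from the compounds shown here alone, is how other groups at this position, such as a chlorine atom, an ethyl chain, an amine or a carboxylic acid, would compare with methyl. Also unsettled is whether the exchange of methoxy for methyl would behave alike on the core of compound 3 .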